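This account rests on a few compounds, and the source may have more. Where it says the series, first, only, none or still open, it means among the compounds named here.

Of the compounds shown here, three sharing one core have been tested in an ADME assay on a cell-free system (plasma, Homo sapiens) for metabolic stability, read by HPLC (on this read-out higher numbers stand for a longer-lived compound and lower numbers for a shorter-lived compound), so far. In this assay compound 1 (`CCCC(CCC)C(=O)N(C)/N=N/c1ccc(C(C)=O)cc1`) gives > 40 h as a limit, not a number. Compound 2 (`CCCC(CCC)C(=O)N(C)/N=N/c1ccc(Cl)cc1`) gives > 40 h as a limit too. Compound 3 (`CCCC(CCC)C(=O)N(C)/N=N/c1ccc(Br)cc1`), the starting point of this account, gives > 40 h and this is also a limit, so its standing has no exact number. Taken together, the record shows the limit of > 40 h in this assay, at which 3 of the 3 values shown sit, and gives no exact half-life for any of the three.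

Among the measured compounds shown here, the compound still to be measured is compound 4 (`CCCC(CCC)C(=O)N(C)/N=N/c1ccc(C)cc1`), which carries methyl in place of bromo on an aromatic carbon as its only change. For the measured compounds named here, the steps that bear on this are those that exchange a group on the same aromatic carbon: a step that the two limits leave unreadable from compound 2 to compound 3 as the closest, then a step that the two limits leave unreadable from compound 1 to compound 2 and a step that the two limits leave unreadable from compound 1 to compound 3 as the other two. Since a step that the two limits leave unreadable from compound 2 to compound 3 has no readable size, no direction follows from it, and the other two add none. The expected step that the limit leaves unreadable from compound 3 to compound 4 is estimated to lie within the usual scatter, with no direction. For compound 4 the estimated half-life is 50 h with an expected range from 25 h to 100 h and a report as a limit is likely once more.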

Compound 4, half-life in the Homo sapiens assay: > 40 h
Compound 4: a limit, no number (the forecaster's own chance of this, stated with the estimate: 75%); the middle value lies beyond the limit too.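

In the Homo sapiens assay compound 4 gives > 40 h as a limit, not a number.

In the Homo sapiens assay no new step can be read between compound 4 and compound 1, compound 2 or compound 3, because all four compounds share one limit: the limit of > 40 h in the Homo sapiens assay, at which 4 of the 4 values shown sit.

The compounds shown leave open how far their half-lives in the Homo sapiens assay lie beyond that limit, and whether acetyl, chloro, bromo and methyl on the aromatic carbon differ there at all.

In a physicochemical assay for pharmacokinetics, read by HPLC, in phosphate buffer, at pH 7.4 (a higher number here means that the compound lasts longer, a lower number that the compound disappears faster), compound 3 gives 30.4 h and compound 4 gives 31.3 h with a 1.0-fold higher number from compound 3 to compound 4 (0.01 log units; within the scatter) for methyl in place of bromo on an aromatic carbon.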